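A few compounds are considered here, and "the series" means these few. Any claim that something is new, unique, unknown or untested is made for them only; others in the source may bear on it.

Measured so far:
Compound 1 `COc1ccc(C2CC(c3ccc(OC)c(OC)c3)=NN2)c(OC)c1` gives 42% in a functional assay on the whole organism (strain albino) for inhibition, with Rattus norvegicus as the target, read by paw edema, with stated times of 30 min and 3 h, at a dose of 100 mg/kg by the oral route; a higher number here means more inhibition at the dose given (going by the name of the read-out), a lower number less inhibition.
Compound 2 `COc1ccc(C2=NN(C(=O)CO[N+](=O)[O-])C(c3ccco3)C2)cc1OC` gives 43% in this assay.

Compound 2 and compound 1 give numbers that lie within the usual scatter of each other, so neither can be set above the other. Compound 3 `COc1ccc(C2CC(c3ccc(OC)c(OC)c3)=NN2C(=O)CO[N+](=O)[O-])c(OC)c1` differs from compound 2 in one place: 2,4-dimethoxyphenyl in place of furan-2-yl on a saturated ring carbon. For the measured compounds named here, no measured pair shows this change on its own, so its effect is unknown. Because compound 1 gives 42% and compound 2 gives 43% while differing in more than one place, no step beyond the scatter is expected; the step expected from compound 2 to compound 3 is a number 2 percentage points higher from compound 2 to compound 3 (within the scatter). Compound 3 is estimated at 45%, between 30% and 60%.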

Compound 3, a percentage reported as inhibition, in the whole organism at one dose (the size of the read-out at that dose, not a potency): 58%
The estimate for compound 3 lay 13 percentage points below the measured number; the range from low to high includes it.
By their numbers in this assay, from the lowest: compounds 1 and 2 (each within the scatter of the next); then compound 3.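

Putting 2,4-dimethoxyphenyl in place of furan-2-yl on the saturated ring carbon gives a number 15 percentage points higher from compound 2 to compound 3 (beyond the scatter) in this assay and shows that the group at this position can change the result. Putting ((nitrooxy)methyl)carbonyl in place of hydrogen on the ring amine nitrogen gives a number 16 percentage points higher from compound 1 to compound 3 (beyond the scatter) and shows that this nitrogen can matter too. No measurement at hand explains either step.

As far as these compounds go, it remains open whether a plain phenyl would match 2,4-dimethoxyphenyl on that ring carbon. From the compounds shown here alone, it is also open how an amine in place of the nitrooxy group would fare.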